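Arylthio aminoindan series: methoxy for bromo on the side chain

This account rests on a few compounds, and the source may have more. Where it says the series, first, only, none or still open, it means among the compounds named here.

Compound 1 `C#CCNC1CCc2c(SCCc3ccc(Br)cc3)cccc21` is a propargylamine-bearing aminoindan carrying a thioether-linked 4-bromophenyl chain. In an ADME assay on isolated protein for inhibition of Amine oxidase [flavin-containing] B (Homo sapiens) (on this read-out higher numbers stand for weaker inhibition and lower numbers for stronger inhibition), compound 1 gives 1250 nM, the lowest of the two numbers in hand. Compound 2 `C#CCNC1CCc2c(SCc3ccc(F)cc3F)cccc21` differs in the side chain and in this assay gives 1480 nM; the two values lie within the scatter of each other, so no order between compound 1 and compound 2 can be read from them. Going by the values given here, no pair of measured compounds differs in only one place, so no measured step is available as a guide.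

Compound 3 `C#CCNC1CCc2c(SCCc3ccc(OC)cc3)cccc21` has not yet been measured. Relative to compound 1 the change is methoxy in place of bromo on an aromatic carbon, on an aromatic carbon of a six-membered aromatic ring of carbon only, para to a large group; one bond further out it reads 4-bromophenyl to 4-methoxyphenyl. Nothing in the measured pair speaks to this exchange. The step from compound 1 to compound 3 in this assay is expected to be small, toward a somewhat higher number, and possibly not beyond the scatter, namely a 1.8-fold higher number from compound 1 to compound 3 (0.25 log units; within the scatter). For compound 3 the expected value in this assay is 2200 nM, with a range of 800 nM to 6000 nM.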

Compound 3, half-maximal inhibitory concentration: 4590 nM
Compound 3: middle estimate off by 2.1-fold (0.32 log units), on the low side, within the range that was stated.
By their numbers in this assay, from the lowest: compounds 1 and 2 (each within the scatter of the next); then compound 3.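

Working notes on the side chain: this is the first exchange in the series that can be read at a single place. In this assay, methoxy in place of bromo on an aromatic carbon, para to a large group, gives a 3.7-fold higher number from compound 1 to compound 3 (0.56 log units; beyond the scatter), a modest step beyond the scatter, so this position is not indifferent to what it carries. With the rest of compound 1 unchanged, 4-methoxyphenyl gives a higher number and thus weaker inhibition than 4-bromophenyl, while the earlier pair of compounds could not isolate any single group in this way. No measurement in hand bears on the reason for this step.

The compounds shown leave open whether the trend extends to other groups at this carbon, such as chloro, hydroxy, an amine, a carboxylic acid or the longer ethoxy, since a single step sets no rank order beyond bromo and methoxy. They also leave open whether the same exchange would give a step of similar size on a side chain of another length or with other substituents on the aromatic ring.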